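The source may hold more compounds than are shown below. What is called first, only, known or untested is meant among the compounds shown, and "the series" means these compounds.

Measured compounds:
- Compound 1, `COc1cc(-c2nnc(SCc3ccccc3[N+](=O)[O-])o2)ccc1O`: in a functional assay on cells (T-cell, Mus musculus, strain BALB/c) for inhibition, read by MTT assay, with stated times of 24 h and 72 h (on this read-out higher numbers stand for weaker inhibition and lower numbers for stronger inhibition), compound 1 gives 9600 nM.
- Compound 2, `COc1cc(-c2nnc(SCc3c(F)cccc3F)o2)ccc1O`: in this assay compound 2 gives 10100 nM.
- Compound 3, `COc1cc(-c2nnc(SCc3cccc(Cl)c3)o2)ccc1O`: in this assay compound 3 gives 8290 nM.

The three compounds share one core and differ only in the group attached to the saturated chain carbon bound to a sulfur. Compound 3 sits within the scatter of both compound 1 and compound 2, so the three numbers cannot be told apart.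

The next compound is compound 4, `COc1cc(-c2nnc(SCc3ccccc3C)o2)ccc1O`, which has not yet been measured in this assay. Compared with compound 3 it changes as follows:

2-methylphenyl in place of 3-chlorophenyl on a saturated chain carbon bound to a sulfur

For the measured compounds named here, the one measured step that alters the same group is a 1.2-fold lower number from compound 2 to compound 3 (0.09 log units; within the scatter), and it stayed within the scatter. Going by the values given here, that single step is the only guide, and it suggests that swapping one substituted phenyl for another at this position does little. Compound 4 is therefore expected to give a number close to that of compound 3, with an expected step of a 1.0-fold higher number from compound 3 to compound 4 (0.01 log units; within the scatter). The estimate for compound 4 is 8500 nM, with a range from 4000 nM to 18000 nM.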

Compound 4, half-maximal inhibitory concentration: 8420 nM
Compound 4: the middle estimate sits 1.0-fold (0.00 log units) above what was measured; low and high end bracket the measured number.
By their numbers in this assay, from the lowest: compounds 3, 4, 1 and 2 (each within the scatter of the next).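

In this assay, 2-methylphenyl cannot be told apart from any of the three earlier groups: replacing 3-chlorophenyl gives one step (a 1.0-fold higher number from compound 3 to compound 4 (0.01 log units; within the scatter)), replacing 2,6-difluorophenyl gives another (a 1.2-fold lower number from compound 2 to compound 4 (0.08 log units; within the scatter)), and methyl in place of nitro on an aromatic carbon gives a third (a 1.1-fold lower number from compound 1 to compound 4 (0.06 log units; within the scatter)). A methyl group on the phenyl ring now joins chloro, difluoro and nitro, so all four substituted phenyl groups on the saturated chain carbon bound to a sulfur give numbers within the scatter of each other. Nothing measured here offers a reason for this flat result.

As far as these compounds go, whether a carboxylic acid or an amine on that carbon would move the number beyond the scatter stays open. So does the effect of a longer chain in place of the phenyl group.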